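The source may hold more compounds than are shown below. What is called first, only, known or untested is meant among the compounds shown, and "the series" means these compounds.

Measured in a functional assay on HepG2 cells (Homo sapiens) for antiproliferative activity, read by MTT assay, with a stated time of 48 h; a higher number here means a weaker inhibitor, a lower number a stronger inhibitor:
- compound 1 `O=C(Nc1cccc(CNc2nccnc2Cl)c1)Nc1ccc(F)c(Cl)c1` gives 6750 nM
- compound 2 `O=C(Nc1cccc(CNc2nccnc2Cl)c1)NC1CCCCC1` gives > 40000 nM (a limit of the assay)
- compound 3 `O=C(Nc1cccc(CNc2nccnc2Cl)c1)Nc1ccc(Cl)cc1Br` is not yet measured

Compound 2 has no number of its own, only the limit > 40000 nM. Its change to compound 3 reads (2-bromo-4-chlorophenyl in place of cyclohexyl on an amide-type nitrogen), 2-bromo-4-chlorophenyl in place of cyclohexyl on an amide-type nitrogen. Within the data shown here, one measured step bears on this: an at least 5.9-fold higher number from compound 1 to compound 2 (0.77 log units; beyond the scatter), which came with the opposite swap, cyclohexyl in place of 3-chloro-4-fluorophenyl. Compound 3 again carries a halogen-bearing phenyl, so a move to a lower number in this assay is expected, towards compound 1 at 6750 nM. The expected change is an at least 5.0-fold lower number from compound 2 to compound 3 (0.69 log units; beyond the scatter). For compound 3 the estimate is 8000 nM, with an expected range from 2500 nM to 30000 nM.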

Compound 3, half-maximal inhibitory concentration: 6720 nM
Compound 3: middle estimate off by 1.2-fold (0.08 log units), on the high side, and the stated range covers the measured number.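

On the amide-type nitrogen, a second halogen-bearing phenyl group also gives a clearly lower number than cyclohexyl in this assay: an at least 5.9-fold lower number from compound 2 to compound 3 (0.77 log units; beyond the scatter). That step is only a bound, because compound 2 stands at a limit: the limit of > 40000 nM in this assay, at which 1 of the 3 values shown sits. The two halogen-bearing phenyl groups are not told apart, with a 1.0-fold lower number from compound 1 to compound 3 (0.00 log units; within the scatter).

The compounds shown leave open whether the halogens matter at all or the aromatic ring alone suffices, which an unsubstituted phenyl would separate. Equally open, from the compounds shown here alone, is how a methoxy or a carboxylic acid on that phenyl would read.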